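This account rests on a few compounds, and the source may have more. Where it says the series, first, only, none or still open, it means among the compounds named here.

Compound 1 `N#CC1=C(N)Oc2c(c3nc4ccccc4nc3c3ccccc23)C12C(=O)N(Cc1cnnn1-c1ccccc1Cl)c1ccccc12`: in a functional assay on A549 cells (Homo sapiens) for antiproliferative activity, read by MTT assay, with a stated time of 48 h (on this read-out higher numbers stand for weaker inhibition and lower numbers for stronger inhibition), compound 1 gives 42600 nM.
Compound 2 `CCOc1ccccc1-n1nncc1CN1C(=O)C2(C(C#N)=C(N)Oc3c2c2nc4ccccc4nc2c2ccccc32)c2ccccc21`: in this assay compound 2 is reported only as a limit, > 50000 nM.
Compound 3 `CCc1ccccc1-n1nncc1CN1C(=O)C2(C(C#N)=C(N)Oc3c(N)cc4nc5ccccc5nc4c32)c2ccccc21`: in this assay compound 3 gives 24600 nM.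

Compound 3 holds the lowest of the two numbers; compound 1 is nearest, and the gap between them lies within the scatter. Compound 4 `CCc1cccc(CC)c1-n1nncc1CN1C(=O)C2(C(C#N)=C(N)Oc3c(N)cc4nc5ccccc5nc4c32)c2ccccc21` differs from compound 3 by ethyl in place of hydrogen on an aromatic carbon. For the measured compounds named here, no measured step covers ethyl in place of hydrogen. Going by the values given here, the only step, an at least 1.1-fold higher number from compound 1 to compound 2 (0.06 log units; that floor lies within the scatter), exchanges one group for another on the same ring and ends at the limit of > 50000 nM in this assay, at which 1 of the 3 values shown sits, so it gives no direction. No step beyond the scatter is therefore expected: a 1.2-fold higher number from compound 3 to compound 4 (0.09 log units; within the scatter). Compound 4 is estimated at 30000 nM in this assay, between 12000 nM and 50000 nM.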

Compound 4, half-maximal inhibitory concentration: > 50000 nM
Compound 4 gave a limit, no number; the forecaster's own chance of this, stated with the estimate: 30%; middle value at least 1.6-fold (0.22 log units) away from the limit.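

In this assay, the change from 2-ethylphenyl to 2,6-diethylphenyl gives an at least 2.0-fold higher number from compound 3 to compound 4 (0.30 log units; that floor lies within the scatter). Going by these compounds, compound 4 is a limit and not a number, so the added ethyl shows no gain in inhibition, while the size of any loss stays unknown. Compound 4 is the second compound at this limit: the limit of > 50000 nM in this assay, at which 2 of the 4 values shown sit.

Open, on these data alone, is how methyl, fluoro or an amine on this aromatic carbon would read against compound 3. Also open, as far as these compounds go, is whether the same ethyl change reads alike on the core of compound 1.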